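Aryl swap on the triazole of compound 3

The source may report more compounds than this note shows. Statements on the series, on what has been measured and on what is new or still open speak of the compounds shown alone.

Measured so far, in a functional assay on HCT-116 cells (Homo sapiens) for antiproliferative activity, read by MTT assay, with a stated time of 48 h; a higher number here means a weaker inhibitor, a lower number a stronger inhibitor:
compound 1 `N#CC1=C(N)Oc2c(c3nc4ccccc4nc3c3ccccc23)C12C(=O)N(Cc1cnnn1-c1ccccc1Br)c1ccccc12` gives > 50000 nM
compound 2 `COc1ccccc1-n1nncc1CN1C(=O)C2(C(C#N)=C(N)Oc3c2c2nc4ccccc4nc2c2ccccc32)c2ccccc21` gives > 50000 nM
compound 3 `CCc1ccccc1-n1nncc1CN1C(=O)C2(C(C#N)=C(N)Oc3c(N)cc4nc5ccccc5nc4c32)c2ccccc21` gives 10300 nM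

For the measured compounds named here, compound 3 stands alone as the only compound with a number; the other two sit at the limit of > 50000 nM in this assay, at which 2 of the 3 values shown sit. For compound 1 the result is a limit of the assay, > 50000 nM. For compound 2 the result is likewise a limit, > 50000 nM. Going by the values given here, the single measured step, a step that the two limits leave unreadable from compound 1 to compound 2, is therefore unreadable in size and says nothing about the aryl group on the triazole.

Compound 4 `N#CC1=C(N)Oc2c(N)cc3nc4ccccc4nc3c2C12C(=O)N(Cc1cnnn1-c1ccc(F)c(Cl)c1)c1ccccc12` differs from compound 3 in one place: 3-chloro-4-fluorophenyl in place of 2-ethylphenyl on an aromatic nitrogen. Among the compounds with values here, no measured step touches this position, so there is no basis for expecting a shift beyond the scatter; the expected step is a 1.0-fold lower number from compound 3 to compound 4 (0.01 log units; within the scatter). Compound 4 is therefore estimated at 10000 nM in this assay, with a range from 3000 nM to 35000 nM, the upper end acknowledging that two of three compounds in the set returned only a limit.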

Compound 4, half-maximal inhibitory concentration: > 50000 nM
Compound 4 was reported as a limit (the forecaster's own chance of this, stated with the estimate: 25%); middle value at least 5.0-fold (0.69 log units) away from the limit.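

In this assay, the group on the aromatic nitrogen now has a readable effect on the core of compound 3: 3-chloro-4-fluorophenyl in place of 2-ethylphenyl gives an at least 4.8-fold higher number from compound 3 to compound 4 (0.68 log units; beyond the scatter). For the compounds shown here, the step between compound 1 and compound 2 cannot be read, so this is the first sign that the aryl group at this position can change the result. Compound 4 gives > 50000 nM, a limit of the assay and not a number, and so joins the values that stop there: the limit of > 50000 nM in this assay, at which 3 of the 4 values shown sit.

Going by these compounds, the true size of the step remains open, as does whether it follows from losing the 2-ethyl group or from gaining the chlorine and fluorine. A plain phenyl or a 2-propylphenyl on the core of compound 3 would help to separate these two readings.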